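This account rests on a few compounds, and the source may have more. Where it says the series, first, only, none or still open, it means among the compounds named here.

For the measured compounds named here, compound 2 `Cc1c(O)c(=O)ccn1CC(=O)N/N=C1\C(=O)N(CC(=O)Nc2ccc(Cl)cc2Cl)c2ccccc21` stands as the only compound with a number rather than a limit in a functional assay on A549 cells (Homo sapiens) for cytotoxicity, read by MTT assay, with a stated time of 48 h; a lower number here means that less compound is needed, a higher number that more compound is needed for the effect: compound 2 gives 61500 nM. Compound 1 `CC(=O)Nc1ccc(NC(=O)CN2C(=O)/C(=N\NC(=O)Cn3ccc(=O)c(O)c3C)c3ccccc32)cc1` reaches only > 100000 nM, which is a limit of this assay and not a number. The step of an at least 1.6-fold lower number from compound 1 to compound 2 (0.21 log units; that floor lies within the scatter) is thus known only as a floor, and that floor rests on (the limit of > 100000 nM in this assay, at which 1 of the 2 values shown sits). Compound 3 `Cc1c(O)c(=O)ccn1CC(=O)N/N=C1\C(=O)N(CC(=O)Nc2cccc(Cl)c2)c2ccccc21` differs from compound 2 in the change (3-chlorophenyl in place of 2,4-dichlorophenyl on an amide-type nitrogen). Going by the values given here, the one measured step, which likewise exchanges the group on that amide-type nitrogen, shows no movement beyond the scatter and is the only guide available. No step beyond the scatter is therefore expected in this assay. The estimated step is a 1.2-fold higher number from compound 2 to compound 3 (0.09 log units; within the scatter). Compound 3 is estimated at 75000 nM, with a range from 30000 nM to 200000 nM, and with a real chance that only a limit is reported.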

Compound 3, half-maximal effective concentration: 28000 nM
Beside the measured number, compound 3's estimate is 2.7-fold (0.43 log units) above it, and the stated range ends above it.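

In this assay, the group on the amide-type nitrogen now moves the number beyond the scatter, which the earlier pair could not show: 3-chlorophenyl in place of 2,4-dichlorophenyl gives a 2.2-fold lower number from compound 2 to compound 3 (0.34 log units; beyond the scatter). Set against 4-acetamidophenyl, 3-chlorophenyl gives an at least 3.5-fold lower number from compound 1 to compound 3 (0.55 log units; beyond the scatter). That second step is only a floor, as the value of compound 1 is a limit of the assay and not a number: the limit of > 100000 nM in this assay, at which 1 of the 3 values shown sits.

Compound 2 and compound 3 differ both in the number of chlorines and in where they stand, so the compounds shown do not separate these two changes. They also leave open how an unsubstituted phenyl, a benzyl or a pyridyl group would read on this nitrogen.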